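The source may report more compounds than this note shows. Statements on the series, on what has been measured and on what is new or still open speak of the compounds shown alone.

Three compounds share one core and differ only in the small aromatic ring attached to the saturated chain carbon bound to an amine nitrogen in a ring. Compound 1 `Cn1cnc(CN2CCN(c3cccc4[nH]c(-c5ccc(C(C)(C)C)cc5)nc34)CC2)c1` gives 33 nM in an assay on isolated protein for displacement of a labelled ligand from Gonadotropin-releasing hormone receptor (Homo sapiens); on this read-out higher numbers stand for weaker inhibition and lower numbers for stronger inhibition; compound 2 `CCc1nc(C)c(CN2CCN(c3cccc4[nH]c(-c5ccc(C(C)(C)C)cc5)nc34)CC2)s1` gives 20 nM; compound 3 `Cc1n[nH]c(C)c1CN1CCN(c2cccc3[nH]c(-c4ccc(C(C)(C)C)cc4)nc23)CC1` gives 68 nM, the highest of the three numbers. The steps ran a 2.1-fold higher number from compound 1 to compound 3 (0.31 log units; beyond the scatter) and a 3.4-fold higher number from compound 2 to compound 3 (0.53 log units; beyond the scatter), both modest. Compound 4 `Cc1cc(CN2CCN(c3cccc4[nH]c(-c5ccc(C(C)(C)C)cc5)nc34)CC2)nn1C` is not yet measured; it differs from compound 3 by 1,5-dimethyl-1H-pyrazol-3-yl in place of 3,5-dimethyl-1H-pyrazol-4-yl on a saturated chain carbon bound to an amine nitrogen in a ring. The same atoms are joined differently, and the earlier ring swaps moved the number only modestly, so a small step is expected, if anything toward a lower number: a 1.5-fold lower number from compound 3 to compound 4 (0.18 log units; within the scatter). For compound 4 the estimate is 45 nM, with a range from 18 nM to 120 nM.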

Compound 4, half-maximal inhibitory concentration: 83 nM
Estimate against measurement, compound 4: 1.8-fold (0.27 log units) below; the range from low to high includes it.
By their numbers in this assay, from the lowest: compounds 2 and 1 (each within the scatter of the next); then compounds 3 and 4 (each within the scatter of the next).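

Replacing 3,5-dimethyl-1H-pyrazol-4-yl, with 1 hydrogen-bond donor, by 1,5-dimethyl-1H-pyrazol-3-yl, with 0 hydrogen-bond donors, gave a 1.2-fold higher number from compound 3 to compound 4 (0.09 log units; within the scatter), so these two pyrazoles cannot be told apart at this position. Compound 4 also reads weaker than the other two rings, with a 2.5-fold higher number from compound 1 to compound 4 (0.40 log units; beyond the scatter) and a 4.2-fold higher number from compound 2 to compound 4 (0.62 log units; beyond the scatter), as compound 3 already did. No measurement here explains these steps.

Still open, going by these compounds, is whether a plain phenyl ring, or a ring carrying an amine, on this same chain carbon would give a lower or a higher number.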